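The compounds below may be only part of what the source reports. "The series", "measured", "known", "first", "only" and "open" are said of these compounds alone.

Measured compounds:
Compound 1, `S=C(Nc1ccccc1)N1N=C(c2ccccc2)CC1c1ccc2c(c1)OCCO2`, gives 3180 nM in a functional assay on WM 266-4 cells (Homo sapiens) for antiproliferative activity, read by MTT assay, with a stated time of 48 h; on this read-out higher numbers stand for weaker inhibition of growth and lower numbers for stronger inhibition of growth.
Compound 2, `S=C(Nc1ccccc1)N1N=C(c2ccc(Br)cc2)CC1c1ccc2c(c1)OCCO2`, gives 870 nM in this assay.

Going by the values given here, compound 2 holds the lowest of the two numbers measured so far; the only comparison available is a 3.7-fold lower number from compound 1 to compound 2 (0.56 log units; beyond the scatter). The unmeasured compound 3, `Cc1ccc(C2=NN(C(=S)Nc3ccccc3)C(c3ccc4c(c3)OCCO4)C2)cc1`, differs from compound 2 in a single place: methyl in place of bromo on an aromatic carbon. Just one measured step touches this position, the exchange of hydrogen for bromo on that aromatic carbon, and it produced a 3.7-fold lower number from compound 1 to compound 2 (0.56 log units; beyond the scatter). Among the compounds with values here, no measured compound carries methyl at that place, so its effect can only be judged from the fact that hydrogen went with the higher number of compound 1 and bromo with the lower number of compound 2. A methyl group there is expected to leave compound 3 somewhere between those two outcomes, so the step of a 1.6-fold higher number from compound 2 to compound 3 (0.21 log units; within the scatter) is expected to be small, towards a higher number, and possibly within the scatter. Compound 3 is therefore estimated at 1400 nM in this assay, with a range from 600 nM to 3500 nM.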

Compound 3, concentration for 50% growth inhibition: 10300 nM
For compound 3 the middle estimate is 7.4-fold (0.87 log units) below the measured one; the whole stated range lies below it.
By their numbers in this assay, from the lowest: compound 2; then compound 1; then compound 3.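

The earlier pair allowed hydrogen and bromo to be read as the two ends of a simple scale, but methyl falls outside that span in this assay. The change from 4-bromophenyl to 4-methylphenyl gives a 12-fold higher number from compound 2 to compound 3 (1.07 log units; beyond the scatter) and methyl in place of hydrogen gives a 3.2-fold higher number from compound 1 to compound 3 (0.51 log units; beyond the scatter) at the same place. Relative to hydrogen, bromo and methyl therefore move the number in opposite directions, even though each counts as a single heavy atom, so this position on the aromatic ring distinguishes sharply between two groups of the same heavy-atom count, and nothing available here accounts for that difference.

With only hydrogen, bromo and methyl shown at this place, it remains open whether chloro or fluoro would give numbers like that of bromo, and whether methoxy, an amine or a longer chain such as ethyl would give numbers like that of methyl. From the compounds shown here alone, it is also open whether the same exchanges would have a similar effect on a different core or at another place on this ring.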